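A few compounds are considered here, and "the series" means these few. Any claim that something is new, unique, unknown or untested is made for them only; others in the source may bear on it.

In a functional assay on MCF7 cells (Homo sapiens) for antiproliferative activity (a lower number here means a stronger inhibitor, a higher number a weaker inhibitor), compound 1 `COc1ccc(Oc2ccc3cc(NC(=O)c4ccc(O)c(CC=C(C)C)c4)c(=O)oc3c2C)cc1` gives 6510 nM, and compound 3 `COc1ccc(Cc2ccc3cc(NC(=O)c4ccc(O)c(CC=C(C)C)c4)c(=O)oc3c2C)cc1OC` gives 13900 nM, the higher of the two numbers, after a step of a 2.1-fold higher number from compound 1 to compound 3 (0.33 log units; beyond the scatter). Compound 2 `COc1ccc(Nc2ccc3cc(NC(=O)c4ccc(O)c(CC=C(C)C)c4)c(=O)oc3c2C)cc1` reaches only the limit of this assay, > 100000 nM. Compound 4 `COc1cc(Cc2ccc3cc(NC(=O)c4ccc(O)c(CC=C(C)C)c4)c(=O)oc3c2C)ccc1O` differs from compound 3 by hydrogen in place of methyl on an oxygen on an aromatic ring. Among the measured compounds shown here, none of the measured steps touches such an oxygen: an at least 15-fold higher number from compound 1 to compound 2 (1.18 log units; beyond the scatter) and an at least 7.1-fold lower number from compound 2 to compound 3 (0.85 log units; beyond the scatter) exchange the whole group on the aromatic carbon of the shared core, not a methyl on an oxygen. For the measured compounds named here, no measured step therefore bears directly on this change, and a step no larger than the scatter is expected, a 1.0-fold higher number from compound 3 to compound 4 (0.00 log units; within the scatter). Compound 4 is accordingly estimated at 14000 nM, expected to lie between 5000 nM and 40000 nM.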

Compound 4, half-maximal inhibitory concentration: 14600 nM
Compound 4: the middle estimate sits 1.0-fold (0.02 log units) below what was measured; measured number inside the range.
By their numbers in this assay, from the lowest: compound 1; then compounds 3 and 4 (each within the scatter of the next). At a limit, above all of these: compound 2.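

In this assay, methoxy to hydroxy on the benzyl group is a step within the scatter: a 1.1-fold higher number from compound 3 to compound 4 (0.02 log units; within the scatter). The hydroxy compound stays apart from both other linked groups, with a 2.2-fold higher number from compound 1 to compound 4 (0.35 log units; beyond the scatter) and an at least 6.8-fold lower number from compound 2 to compound 4 (0.83 log units; beyond the scatter). The second of these steps is only a bound, compound 2 standing at a limit: the limit of > 100000 nM in this assay, at which 1 of the 4 values shown sits.

Open, as far as these compounds go, is whether an amine or a carboxylic acid in place of that hydroxy would also stay within the scatter of compound 3. Also open, from the compounds shown here alone, is whether methoxy to hydroxy on the 4-methoxyphenoxy group of compound 1 would give a similar step.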